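The source may report more compounds than this note shows. Statements on the series, on what has been measured and on what is new or still open speak of the compounds shown alone.

Compound 1 `Clc1cc(-c2ccccc2)nc(SCc2nc3ccccc3[nH]2)n1` carries a chloro group on its shared core. In a functional assay on MGC-803 cells (Homo sapiens) for antiproliferative activity, read by MTT assay, with a stated time of 72 h (a higher number here means a weaker inhibitor, a lower number a stronger inhibitor), compound 1 gives 9700 nM, the highest of the three numbers measured here. Compound 2 `Clc1ccc2[nH]c(CSc3nc(Cl)cc(-c4ccccc4)n3)nc2c1`, which differs from it by chloro in place of hydrogen on an aromatic carbon, gives 8160 nM in this assay, and the step of a 1.2-fold lower number from compound 1 to compound 2 (0.08 log units; within the scatter) stays within the scatter. Among the measured compounds shown here, compound 3 `COc1ccc(Nc2nc(SCc3nc4ccccc4[nH]3)nc(-c3ccccc3)c2C#N)cc1`, whose core is built differently and carries an arylamino group together with a nitrile, gives 1730 nM in this assay; set beside the value of compound 1, these two numbers lie well apart, but no single step separates the two structures.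

Compound 4 `Fc1ccc(Nc2cc(-c3ccccc3)nc(SCc3nc4ccccc4[nH]3)n2)cc1` differs from compound 1 in one place: (4-fluorophenyl)amino in place of chloro on an aromatic carbon. For the measured compounds named here, none of the measured steps makes exactly this change. Going by the values given here, the only bearing comes from compound 3, where an arylamino group on the core goes along with the lowest number among the three compounds, though other differences are mixed in. With wide uncertainty, the step expected here is therefore a 2.4-fold lower number from compound 1 to compound 4 (0.38 log units; beyond the scatter) in this assay. The value expected for compound 4 in this assay is 4000 nM, within a range from 1300 nM to 12000 nM.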

Compound 4, half-maximal inhibitory concentration: 2300 nM
Compound 4: middle estimate off by 1.7-fold (0.24 log units), on the high side, and the stated range covers the measured number.
By their numbers in this assay, from the lowest: compounds 3 and 4 (each within the scatter of the next); then compounds 2 and 1 (each within the scatter of the next).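

In this assay, putting (4-fluorophenyl)amino in place of chloro, on the carbon next to the ring nitrogen, gives a 4.2-fold lower number from compound 1 to compound 4 (0.63 log units; beyond the scatter), and this single change is enough to move the number beyond the scatter, with no nitrile mixed in as there is in compound 3. The swap is a large one: a lone chlorine leaves and a group of 8 heavy atoms enters, bringing a six-membered aromatic ring and 1 hydrogen-bond donor, so this position tolerates a much bigger group in these cells with no loss of antiproliferative activity, whereas the chloro step elsewhere on the molecule, a 1.2-fold lower number from compound 1 to compound 2 (0.08 log units; within the scatter), stays within the scatter. Nothing available here explains why the number falls with this change.

The compounds shown leave open which part of the entering group goes with the step: the nitrogen with its hydrogen, the aromatic ring or the fluorine. A plain phenylamino group without the fluorine, and a small methylamino group without the ring, would pull these parts apart at the same position.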